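The source may report more compounds than this note shows. Statements on the series, on what has been measured and on what is new or still open speak of the compounds shown alone.

Measured compounds:
- compound 2 `C=CCc1cc(C(C)=O)c(O)cc1OCCCCCC#N`: 81% in an assay on isolated protein for inhibition of leukotriene B4 receptor 1 (Homo sapiens), tested at 10 uM; on this read-out lower numbers stand for less inhibition and higher numbers for more inhibition at the one concentration tested (going by the name of the read-out)
- compound 1 `CC(=O)c1cc(CC(C)O)c(OCCCCC#N)cc1O`: 10% in this assay

Compound 2 stands highest of the two numbers shown, and compound 1 lies far below it, a gap well beyond the scatter. Compound 3 `C=CCc1cc(C(C)=O)c(O)cc1OCCCCCC(C)(C)O` is not yet measured; it differs from compound 2 in one place: 1-hydroxy-1-methylethyl in place of cyano on a saturated chain carbon, five bonds along the chain from an oxygen on an aromatic ring. Among the measured compounds shown here, no measured pair shows this kind of change, so the size of its effect is unknown. The step from compound 2 to compound 3 is expected to be a number 26 percentage points lower from compound 2 to compound 3 (beyond the scatter), a decrease beyond the scatter. Compound 3 is estimated at 55%, within a range from 20% to 85%.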

Compound 3, a percentage reported as inhibition, at one concentration (the size of the read-out at that concentration, not a potency): 98%
Estimate against measurement, compound 3: 43 percentage points below; measured number above the stated range.
By their numbers in this assay, from the lowest: compound 1; then compound 2; then compound 3.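

With 1-hydroxy-1-methylethyl in place of cyano on a saturated chain carbon, five bonds along the chain from an oxygen on an aromatic ring, this assay gives a number 17 percentage points higher from compound 2 to compound 3 (beyond the scatter). The cyano group is therefore not required at this position, and a larger group carrying a hydrogen-bond donor is accepted there. Nothing available explains this gain. From the compounds shown here alone, it remains open whether a carboxylic acid or an amine at the same chain end would hold this level of inhibition. A single concentration also leaves the potency of compound 3 undefined.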